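Compound 4 and the 2,3-dichlorophenyl change

The compounds below may be only part of what the source reports. "The series", "measured", "known", "first", "only" and "open" are said of these compounds alone.

compound 1 `O=C(/C(=C\c1ccc(O)c([N+](=O)[O-])c1)SCc1ccc(Cl)cc1)c1ccc(Cl)cc1` 10000 nM
compound 2 `Cc1ccc(/C=C(/SCc2ccc(Cl)cc2)C(=O)c2ccc(Cl)cc2)s1` 50000 nM
compound 3 `Cc1ccc(C)c(/C=C(/SCc2ccc(Cl)cc2)C(=O)c2ccc(Cl)cc2)c1` 10000 nM

Compound 3 stands in a functional assay on DU-145 cells (Homo sapiens) for inhibition, read by trypan blue exclusion, with a stated time of 96 h (a higher number here means a weaker inhibitor of growth, a lower number a stronger inhibitor of growth), at 10000 nM and is level with compound 1, the two sharing the lowest number of the three. Compound 4 `O=C(/C(=C\c1cccc(Cl)c1Cl)SCc1ccc(Cl)cc1)c1ccc(Cl)cc1` has 2,3-dichlorophenyl in place of 2,5-dimethylphenyl on a double-bonded chain carbon bound to a double-bonded chain carbon on a double-bonded chain carbon bound to a double-bonded chain carbon. The measured steps at this same place bear on it. The step of no change at the digits printed from compound 1 to compound 3 (within the scatter) exchanged one substituted phenyl for another and stays within the scatter. The step of a 5.0-fold lower number from compound 2 to compound 3 (0.70 log units; beyond the scatter) exchanged 5-methylthiophen-2-yl for a substituted phenyl and goes beyond it. Within the data shown here, compound 4 keeps a substituted phenyl, but no measured step exchanges methyl for chlorine, so this expectation is only indirect. What is expected is a 1.2-fold higher number from compound 3 to compound 4 (0.08 log units; within the scatter) in this assay and no step beyond the scatter. Compound 4 is estimated at 12000 nM with an expected range from 4000 nM to 35000 nM in this read-out.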

Compound 4, concentration for 50% growth inhibition: 10000 nM
Estimate against measurement, compound 4: 1.2-fold (0.08 log units) above; measured number inside the range.
By their numbers in this assay, from the lowest: compounds 1, 3 and 4 (each within the scatter of the next); then compound 2.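

In this assay, the 2,3-dichlorophenyl group gives no change at the digits printed from compound 3 to compound 4 (within the scatter) and no change at the digits printed from compound 1 to compound 4 (within the scatter), so three differently substituted phenyl groups now share one level at this place on a double-bonded chain carbon. The separation from 5-methylthiophen-2-yl also holds for the new group, with a 5.0-fold lower number from compound 2 to compound 4 (0.70 log units; beyond the scatter), and it now rests on three phenyl compounds rather than two. No experimental evidence bears on this result.

Going by these compounds, whether an amine, a carboxylic acid or a longer chain on the phenyl ring at this place would shift the number away from the level of compound 1, compound 3 and compound 4 remains open. Also open, on these data alone, is whether the step from 5-methylthiophen-2-yl follows from the thiophene ring itself or from its methyl group, which an unsubstituted thiophene could help separate.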